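A few compounds are considered here, and "the series" means these few. Any claim that something is new, unique, unknown or untested is made for them only; others in the source may bear on it.

Compound 2 `Cc1sc2ccc(Cl)cc2c1C1C=CN=CN1` is the compound that needed the least material here: in a functional assay on the whole organism with Mus musculus as the target, with a stated time of 15 min (a higher number here means that more compound is needed for the effect, a lower number that less compound is needed), compound 2 gives 3 mg/kg, while compound 1 `Cc1sc2ccccc2c1C1NC=Nc2cc(F)ccc21` gives 30 mg/kg, a higher number that lies beyond the scatter. Compound 3 `Cc1sc2ccccc2c1C1C=CN=CN1` has not yet been tested. It differs from compound 2 by hydrogen in place of chloro on an aromatic carbon. Going by the values given here, no measured pair shows this change alone, so the expectation rests on the loss of the chloro group itself. A modest rise in the number is expected, the step being a 2.3-fold higher number from compound 2 to compound 3 (0.37 log units; beyond the scatter). Compound 3 is therefore expected to give about 7 mg/kg, within 2 mg/kg to 30 mg/kg.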

Compound 3, minimum effective dose: 3 mg/kg
Compound 3: middle estimate off by 2.3-fold (0.37 log units), on the high side; low and high end bracket the measured number.
By their numbers in this assay, from the lowest: compounds 2 and 3 (each within the scatter of the next); then compound 1.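

In this assay, hydrogen in place of chloro on this aromatic carbon gives no change at the digits printed from compound 2 to compound 3 (within the scatter), so the chloro group is not required here for the effect in the mouse. This is the first single-place comparison among these compounds, since compound 1 differs from the others in more than one place. Nothing measured here explains this result. On these data alone, it remains open whether a larger group at this carbon, such as methoxy, trifluoromethyl or an amine, would leave the number unchanged. Going by these compounds alone, the same question stands for the methyl group on the shared core, which no pair of compounds varies.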